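Acetyl for isopropylcarbonyl carried onto a second core

This account rests on a few compounds, and the source may have more. Where it says the series, first, only, none or still open, it means among the compounds named here.

Measured values, all from an assay on HEK293 cells for positive allosteric modulation of metabotropic glutamate receptor 3 (Rattus norvegicus), read by thallium flux, with a stated time of 2.5 min; a higher number here means a larger maximal response, a lower number a smaller maximal response:

compound 1 `Cc1cc(C(=O)O)ccc1OCCCCOc1ccc(C(=O)C(C)C)c(O)c1C` gives 25.2%
compound 2 `CC(=O)c1ccc(OCCCCOc2ccc(C(=O)O)cc2C)c(C)c1O` gives 25.4%
compound 3 `Cc1c(OCCCCOc2ccc(F)c(C(=O)O)c2)ccc(C(=O)C(C)C)c1O` gives 31.3%

Compound 1 and compound 2 share one core and differ in a single place, (methyl in place of isopropyl on a carbonyl carbon). The step that this change made in the assay is a number 0.2 percentage points higher from compound 1 to compound 2 (within the scatter). Compound 3 is built on a different core; how its core differs from that of compound 1 is not broken down here. The value of compound 3 lies within the scatter of the values of compound 2 and of compound 1, so the three measured compounds show no separation in this assay.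

Compound 4 `CC(=O)c1ccc(OCCCCOc2ccc(F)c(C(=O)O)c2)c(C)c1O` has not been measured. It differs from compound 3 by methyl in place of isopropyl on a carbonyl carbon, and the description of the place is the same word for word as for the change from compound 1 to compound 2, so this is the same change, now carried onto the core of compound 3. It occurs twice among the four compounds, once measured and once pending.

The step from compound 3 to compound 4 in this assay is expected to be small, estimated at a number 0.3 percentage points lower from compound 3 to compound 4 (within the scatter), because the same change measured on the other core gave a number 0.2 percentage points higher from compound 1 to compound 2 (within the scatter). Going by the values given here, nothing among the measured compounds indicates that the core of compound 3 would answer this change differently, though a single prior instance is thin support. Compound 4 is therefore estimated at 31%, with a likely range from 24% to 38%.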

Compound 4, largest response reached (reported as percent of maximum), in percent of the reference or control that the assay uses: 16.8%
The estimate for compound 4 lay 14.2 percentage points above the measured number; the measured number lies below the stated range.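

In this assay, acetyl in place of isopropylcarbonyl does not behave as a fixed step that can be carried from one core to another: the same change on two cores in this assay, a number 0.2 percentage points higher (within the scatter) from compound 1 to compound 2 and a number 14.5 percentage points lower (beyond the scatter) from compound 3 to compound 4, 14.7 percentage points apart, beyond the scatter of two such steps. On the core of compound 3 the change gives a number 14.5 percentage points lower from compound 3 to compound 4 (beyond the scatter), so the near-silent result on the core of compound 1 does not predict the outcome here, and the effect of this change in the series depends on the core that carries it. This rests on a single matched pair per core, so it does not show which feature of the two cores separates them, nor how the change would behave on any further core.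

Still open, on these data alone, is how other groups on the carbonyl carbon, such as ethyl, cyclopropyl or a longer chain, would fall on each of the two cores, and whether the response on the core of compound 3 rises steadily with the size of that group or is specific to isopropyl. Also open, as far as these compounds go, is whether the loss seen on the core of compound 3 would persist with an amide or a tetrazole in place of the carboxylic acid.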